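Dimethylamino replacing hydroxy on the anilide ring

The source may report more compounds than this note shows. Statements on the series, on what has been measured and on what is new or still open speak of the compounds shown alone.

In a functional assay on stomach for binding affinity to Gastrin/cholecystokinin type B receptor (Rattus norvegicus) (a higher number here means weaker binding, a lower number tighter binding), compound 2 `CC(C)(C)C(=O)CN1C(=O)N(CC(=O)Nc2cccc(O)c2)N=C(C2CCCCC2)c2ccccc21` gives 27.5 nM, the lowest of the three numbers measured: compound 1 `CNCCN(C)c1cccc(NC(=O)CN2N=C(C3CCCCC3)c3ccccc3N(CC(=O)C(C)(C)C)C2=O)c1` gives 117 nM and compound 3 `CNc1cccc(NC(=O)CN2N=C(c3ccccc3)c3ccccc3N(CC(=O)C(C)(C)C)C2=O)c1` gives 132 nM. Compound 4 `CN(C)c1cccc(NC(=O)CN2N=C(C3CCCCC3)c3ccccc3N(CC(=O)C(C)(C)C)C2=O)c1` has not yet been measured; it differs from compound 2 by dimethylamino in place of hydroxy on an aromatic carbon. The measured step that bears on this is a 4.3-fold lower number from compound 1 to compound 2 (0.63 log units; beyond the scatter), a change at the same aromatic carbon from a larger amino group to hydroxy. Compound 3, which carries methylamino there but also phenyl in place of cyclohexyl, gives a value close to that of compound 1, so both amino-bearing compounds sit well above compound 2. The change to compound 4 runs in the opposite direction to that step, so a modest rise is expected, perhaps somewhat smaller because the step of a 4.3-fold lower number from compound 1 to compound 2 (0.63 log units; beyond the scatter) involved a bulkier group than dimethylamino. The expected step is a 2.9-fold higher number from compound 2 to compound 4 (0.46 log units; beyond the scatter). Compound 4 is therefore estimated at 80 nM in this assay, with a range from 30 nM to 220 nM.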

Compound 4, dissociation constant: 91.2 nM
Beside the measured number, compound 4's estimate is 1.1-fold (0.06 log units) below it, within the range that was stated.
By their numbers in this assay, from the lowest: compound 2; then compounds 4, 1 and 3 (each within the scatter of the next).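

In this assay, the step from hydroxy to dimethylamino on the same aromatic carbon, a 3.3-fold higher number from compound 2 to compound 4 (0.52 log units; beyond the scatter), shows that the higher number does not require the longer side chain of compound 1. Cutting that chain back gives a 1.3-fold lower number from compound 1 to compound 4 (0.11 log units; within the scatter), so this position does not separate the two amino groups, and among the cyclohexyl compounds, hydroxy alone stands apart. Nothing available accounts for the difference between hydroxy and dimethylamino.

A methoxy group or an unsubstituted amine on this aromatic carbon would show whether the lower number of compound 2 belongs to hydroxy specifically or is shared by other small groups. As far as these compounds go, whether hydroxy gives a similar step with phenyl in place of cyclohexyl also stays open.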